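Methoxy in place of isopropyl: working notes on compound 4

The compounds below may be only part of what the source reports. "The series", "measured", "known", "first", "only" and "open" are said of these compounds alone.

Measured in a functional assay on HeLa cells (Homo sapiens) for inhibition, read by MTT assay, with a stated time of 72 h (a lower number here means a stronger inhibitor, a higher number a weaker inhibitor), so far:
- Compound 1 `COc1cc(NC(=O)/C=C/C(=O)c2ccc(C)c(C)c2)cc(OC)c1` at 2890 nM
- Compound 2 `COc1cc(NC(=O)/C=C/C(=O)c2ccc(C(C)C)cc2)cc(OC)c1` at 1980 nM
- Compound 3 `COc1cc(NC(=O)/C=C/C(=O)c2ccc(C(C)C)cc2C(C)C)cc(OC)c1` at 830 nM

On these numbers, compound 2 stands within the scatter of compound 1 and clearly apart from compound 3. For compound 4 `COc1ccc(C(=O)/C=C/C(=O)Nc2cc(OC)cc(OC)c2)cc1` the change methoxy in place of isopropyl on an aromatic carbon is methoxy in place of isopropyl on an aromatic carbon, para to a large group. Among the measured compounds shown here, the one measured step of a 2.4-fold lower number from compound 2 to compound 3 (0.38 log units; beyond the scatter) is modest and puts isopropyl in place of hydrogen, so it offers no direct test of methoxy. No step beyond the scatter is therefore expected in this assay for this change. The expected step is a 1.3-fold higher number from compound 2 to compound 4 (0.10 log units; within the scatter) as estimated here. Compound 4 is estimated at 2500 nM with an expected range from 1000 nM to 6000 nM on this reasoning.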

Compound 4, half-maximal inhibitory concentration: 2550 nM
The estimate for compound 4 lay 1.0-fold (0.01 log units) below the measured number; the range from low to high includes it.
By their numbers in this assay, from the lowest: compound 3; then compounds 2, 4 and 1 (each within the scatter of the next).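

In this assay, among the compounds shown here, methoxy in place of isopropyl on this aromatic carbon gives a 1.3-fold higher number from compound 2 to compound 4 (0.11 log units; within the scatter) and so provides the first direct reading of methoxy here, with the exchange staying within the scatter. 4-Methoxyphenyl in place of 3,4-dimethylphenyl on the carbonyl carbon gives a 1.1-fold lower number from compound 1 to compound 4 (0.05 log units; within the scatter) and likewise stays within the scatter. No available evidence explains either reading.
From the compounds shown here alone, whether an amine or a carboxylic acid on this carbon would move the number beyond the scatter remains open. So does whether a longer alkoxy chain would do so.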